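Moving the fluorine around the ring: compound 4 expected

A few compounds are considered here, and "the series" means these few. Any claim that something is new, unique, unknown or untested is made for them only; others in the source may bear on it.

Three compounds have been measured in a functional assay on MDA-MB-231 cells (Homo sapiens) for cytotoxicity, read by MTT assay, with a stated time of 48 h; a higher number here means a weaker inhibitor, a lower number a stronger inhibitor:
compound 1 `O=C(/C=C/c1ccc2c(c1)B(O)OC2)c1ccccc1` gives 2300 nM;
compound 2 `Cc1ccc(C(=O)/C=C/c2ccc3c(c2)B(O)OC3)cc1` gives 6500 nM;
compound 3 `O=C(/C=C/c1ccc2c(c1)B(O)OC2)c1ccccc1F` gives 2200 nM.

Compound 3 has the lowest number of the three, yet its value and that of compound 1 are within the scatter of each other, so the two cannot be told apart; only compound 2 stands clearly higher, by a 3.0-fold lower number from compound 2 to compound 3 (0.47 log units; beyond the scatter).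

Compound 4 `O=C(/C=C/c1ccc2c(c1)B(O)OC2)c1cccc(F)c1` keeps the shared core and differs from compound 3 only in the ring on the carbonyl carbon: 3-fluorophenyl in place of 2-fluorophenyl on a carbonyl carbon. For the measured compounds named here, two measured steps bear on this. Adding fluoro to the plain phenyl ring gave a 1.0-fold lower number from compound 1 to compound 3 (0.02 log units; within the scatter), a change within the scatter. Adding methyl instead gave a 2.8-fold higher number from compound 1 to compound 2 (0.45 log units; beyond the scatter), a modest rise. Going by the values given here, no measured pair moves a group from one ring position to another, so the direct effect of the shift is unknown. Since the fluoro in compound 3 (2200 nM) made no difference that went past the scatter, compound 4 is expected to land close to compound 3, a step of a 1.1-fold higher number from compound 3 to compound 4 (0.06 log units; within the scatter). The estimate for compound 4 is 2500 nM, with a range from 1200 nM to 5500 nM.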

Compound 4, half-maximal inhibitory concentration: 3000 nM
Compound 4: middle estimate off by 1.2-fold (0.08 log units), on the low side, within the range that was stated.
By their numbers in this assay, from the lowest: compounds 3, 1 and 4 (each within the scatter of the next); then compound 2.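

In this assay, for the compounds shown here, a group has now moved from one ring position to another for the first time: 3-fluorophenyl in place of 2-fluorophenyl gives a 1.4-fold higher number from compound 3 to compound 4 (0.13 log units; within the scatter) and so leaves the two fluorophenyl compounds indistinguishable. The new fluoro placement likewise cannot be separated from the plain phenyl ring, with a 1.3-fold higher number from compound 1 to compound 4 (0.12 log units; within the scatter) on record, whereas the swap from 4-methylphenyl stays clear at a 2.2-fold lower number from compound 2 to compound 4 (0.34 log units; beyond the scatter) and shows that the gap to compound 2 survives the shift of the fluorine. No outside measurement is available to explain these numbers.

The compounds shown leave open whether the higher number of compound 2 goes with the methyl group itself or with its place in 4-methylphenyl. They also leave open how an amine, a carboxylic acid or a methoxy group on this ring would read.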